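This account rests on a few compounds, and the source may have more. Where it says the series, first, only, none or still open, it means among the compounds named here.

Measured so far in a functional assay on MGC-803 cells (Homo sapiens) for inhibition, read by MTT assay, with a stated time of 72 h; a lower number here means a stronger inhibitor, a higher number a weaker inhibitor: compound 1, `O=C(CSc1nc(Nc2ccccc2)c2ccccc2n1)Nc1cccc(Br)c1`, gives 9620 nM; compound 2, `CCc1cccc(NC(=O)CSc2nc(Nc3ccccc3)c3ccccc3n2)c1`, gives 15800 nM.

Among the measured compounds shown here, compound 2 gives the highest of these two numbers, yet the only known step, a 1.6-fold higher number from compound 1 to compound 2 (0.22 log units; within the scatter), shows that difference to lie within the scatter. The unmeasured compound 3, `CCc1ccc(NC(=O)CSc2nc(Nc3ccccc3)c3ccccc3n2)cc1`, differs from compound 2 by 4-ethylphenyl in place of 3-ethylphenyl on an amide-type nitrogen. For the measured compounds named here, no measured step touches this change; the single step known concerns bromo against ethyl, a different exchange. The step expected, a 1.1-fold lower number from compound 2 to compound 3 (0.02 log units; within the scatter), is therefore none beyond the scatter. Compound 3 is estimated at 15000 nM, with a range from 5000 nM to 45000 nM.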

Compound 3, half-maximal inhibitory concentration: > 50000 nM
Compound 3 gave a limit, no number; the forecaster's own chance of this, stated with the estimate: 10%; middle value at least 3.3-fold (0.52 log units) away from the limit.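

Compound 3 gives a limit, not a number, in this assay: the limit of > 50000 nM in this assay, at which 1 of the 3 values shown sits. With the same atoms joined differently, 4-ethylphenyl in place of 3-ethylphenyl gives an at least 3.1-fold higher number from compound 2 to compound 3 (0.50 log units; beyond the scatter), so where the ethyl sits on this ring counts, something the earlier bromo-to-ethyl step, within the scatter, could not show. The exchange for 3-bromophenyl gives an at least 5.1-fold higher number from compound 1 to compound 3 (0.71 log units; beyond the scatter).

On these data alone, it remains open whether this shift is tied to ethyl or would also appear with 4-bromophenyl. As far as these compounds go, how a methoxy or an amine would fare at either place also stays unknown.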